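Swapping an aromatic amide for a methylpiperidine amide

This account rests on a few compounds, and the source may have more. Where it says the series, first, only, none or still open, it means among the compounds named here.

Compound 3 `CN(C)c1ccc(C(=O)Nc2cccc(Nc3ncc(F)c(Nc4ccc(F)cc4)n3)c2)cc1` sits at a limit: in a functional assay on A549 cells (Homo sapiens) for antiproliferative activity, read by sulforhodamine B assay, with a stated time of 3 days (a higher number here means a weaker inhibitor of growth, a lower number a stronger inhibitor of growth), compound 3 gives > 10000 nM, which is only a limit of the assay, not a number (the limit of > 10000 nM in this assay, at which 1 of the 3 values shown sits). Compound 4 `CN1CCC(C(=O)Nc2cccc(Nc3ncc(F)c(Nc4ccc(F)cc4)n3)c2)CC1` differs in one place: 1-methylpiperidin-4-yl in place of 4-(dimethylamino)phenyl on a carbonyl carbon. The change that bears most on it is the step from compound 1 `CN(C)CC(=O)Nc1cccc(Nc2ncc(F)c(Nc3ccc(F)cc3)n2)c1`, where compound 1 gives 1180 nM, to compound 3, which was an at least 8.4-fold higher number from compound 1 to compound 3 (0.92 log units; beyond the scatter); that step introduced the aromatic ring now being removed. Compound 2 `O=C(Nc1cc(Cl)cc(Cl)c1)c1cccc(Nc2ncc(F)c(Nc3ccc(F)cc3)n2)c1` gives 17500 nM, and a 15-fold higher number from compound 1 to compound 2 (1.17 log units; beyond the scatter) shows another large loss on moving to an aromatic amide partner. Compound 4 is therefore expected to be a stronger inhibitor than compound 3, with an estimated step of an at least 3.3-fold lower number from compound 3 to compound 4 (0.52 log units; beyond the scatter). Compound 4 is estimated at 3000 nM, between 800 nM and 12000 nM.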

Compound 4, concentration for 50% growth inhibition: 1330 nM
Beside the measured number, compound 4's estimate is 2.3-fold (0.35 log units) above it, within the range that was stated.
By their numbers in this assay, from the lowest: compounds 1 and 4 (each within the scatter of the next); then compound 2.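

Replacing 4-(dimethylamino)phenyl with 1-methylpiperidin-4-yl on the carbonyl carbon gives an at least 7.5-fold lower number from compound 3 to compound 4 (0.87 log units; beyond the scatter). Compound 3 is a limit, not a number, so this step has only a bound: the limit of > 10000 nM in this assay, at which 1 of the 4 values shown sits. A non-aromatic ring is tolerated here, as a 1.1-fold higher number from compound 1 to compound 4 (0.05 log units; within the scatter) puts it level with the (dimethylamino)methyl chain, while a 13-fold lower number from compound 2 to compound 4 (1.12 log units; beyond the scatter) separates it from the (3,5-dichlorophenyl)carbamoyl compound.

The compounds shown leave open whether the ring nitrogen matters, which a cyclohexyl group in place of 1-methylpiperidin-4-yl would test. A morpholine ring would ask the same of the ring's other atoms.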